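Swapping a cinnamyl thioether for a branched alkyl chain

The source may report more compounds than this note shows. Statements on the series, on what has been measured and on what is new or still open speak of the compounds shown alone.

Measured so far:
- compound 1, `CCCCCSCCC1C2CCC(O2)C1C/C=C\CCCC(=O)O`: 37000 nM
- compound 2, `O=C(O)CCC/C=C\CC1C2CCC(O2)C1CSC/C=C/c1ccccc1`: 86000 nM

Both compounds were tested in a functional assay on a cell-free system (plasma) with thromboxane A2 receptor (Homo sapiens) as the target; on this read-out higher numbers stand for weaker inhibition and lower numbers for stronger inhibition. Compound 2 gives the higher of the two numbers, 86000 nM, which means it is the weaker inhibitor in the pair, and the gap to compound 1 lies beyond the usual scatter of repeated measurements.

The next compound, compound 3, `CCCCCC(C)SCC1C2CCC(O2)C1C/C=C\CCCC(=O)O`, is not yet measured. Compared with compound 2 it carries the following change: 1-methylhexyl in place of 3-phenylprop-2-en-1-yl on a sulfur. The acid-bearing chain and the bicyclic core stay the same; only the group on the sulfur is exchanged, from an aromatic-containing group to a plain branched chain.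

For the measured compounds named here, the only guide for what to expect is compound 1, whose sulfur likewise carries an unbranched alkyl chain and which gives 37000 nM in this assay. On that basis compound 3 is expected to move toward a lower number than compound 2, with a step of moderate size, a 2.2-fold lower number from compound 2 to compound 3 (0.33 log units; beyond the scatter), though the scatter of the assay leaves room for no real change. The estimate for compound 3 is 40000 nM, with a plausible range from 15000 nM to 110000 nM.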

Compound 3, half-maximal inhibitory concentration: 3800 nM
Estimate against measurement, compound 3: 11-fold (1.02 log units) above; measured number outside the range, below it.
By their numbers in this assay, from the lowest: compound 3; then compound 1; then compound 2.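

In this assay, the group on the sulfur turns out to matter far more than the first two compounds suggested: exchanging 3-phenylprop-2-en-1-yl for 1-methylhexyl gives a large step (a 23-fold lower number from compound 2 to compound 3 (1.35 log units; beyond the scatter)). Compound 3 also clearly separates from compound 1 (a 9.7-fold lower number from compound 1 to compound 3 (0.99 log units; beyond the scatter)), so having a sulfur-bearing chain without a ring does not by itself set the number, and the exact make-up of that chain counts as well. No measurement in this set explains why either step is so large.

The compounds shown leave open whether the gain comes from the methyl branch, from the length of the chain, or from the removal of the phenyl ring and the double bond, which all change together in the step from compound 2. An unbranched heptyl chain on the same sulfur would test the branch against the length, and a cyclohexylmethyl or a saturated 3-phenylpropyl group would show whether a ring as such, or only the double bond, goes with the higher number.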